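The source may report more compounds than this note shows. Statements on the series, on what has been measured and on what is new or still open speak of the compounds shown alone.

Measured in a functional assay on HepG2 cells (Homo sapiens) for inhibition, read by sulforhodamine B assay, with a stated time of 74 h; on this read-out lower numbers stand for stronger inhibition and higher numbers for weaker inhibition:
- compound 1 `CS(=O)(=O)N1C(=O)COC12C=CC(=O)C=C2`: > 10000 nM (a limit of the assay, not a number)
- compound 2 `Cc1ccccc1S(=O)(=O)N1C(=O)COC12C=CC(=O)C=C2`: 750 nM
- compound 3 `O=C1C=CC2(C=C1)OCC(=O)N2S(=O)(=O)c1ccc(Cl)cc1`: 860 nM

Compound 3 cannot be separated from compound 2: a 1.1-fold higher number from compound 2 to compound 3 (0.06 log units; within the scatter). Both replacements of the methyl on the sulfonyl sulfur gave large steps: an at least 13-fold lower number from compound 1 to compound 2 (1.12 log units; beyond the scatter) and an at least 11-fold lower number from compound 1 to compound 3 (1.06 log units; beyond the scatter). Compound 4 `COc1ccc(S(=O)(=O)N2C(=O)COC23C=CC(=O)C=C3)cc1` keeps the ring on the sulfonyl sulfur and has methoxy in place of chloro on an aromatic carbon, para to a large group: methoxy in place of chloro on an aromatic carbon. Among the compounds with values here, the closest precedent is the swap of 2-methylphenyl for 4-chlorophenyl, a 1.1-fold higher number from compound 2 to compound 3 (0.06 log units; within the scatter), so no step beyond the scatter is expected in this assay. The expected step is a 1.1-fold lower number from compound 3 to compound 4 (0.03 log units; within the scatter). For compound 4 the estimated value is 800 nM, with an expected range from 350 nM to 1900 nM.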

Compound 4, half-maximal inhibitory concentration: 1620 nM
Estimate against measurement, compound 4: 2.0-fold (0.31 log units) below, and the stated range covers the measured number.
By their numbers in this assay, from the lowest: compounds 2, 3 and 4 (each within the scatter of the next, the first and the last beyond it). At a limit, above all of these: compound 1.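

In this assay, methoxy in place of chloro on an aromatic carbon, para to a large group, gives a 1.9-fold higher number from compound 3 to compound 4 (0.28 log units; within the scatter). This is the first swap shown at this position with the rest of the molecule held fixed, and the two groups cannot be separated here. The position therefore accepts either chloro or methoxy without a step beyond the scatter.

Going by these compounds, an amine or a carboxylic acid at this position remains open, as does a phenyl ring without any group there. Compound 1 stands at a limit, so the full size of the steps from it to the compounds with a ring on the sulfonyl sulfur stays undefined: the limit of > 10000 nM in this assay, at which 1 of the 4 values shown sits.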